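The source may hold more compounds than are shown below. What is called first, only, known or untested is meant among the compounds shown, and "the series" means these compounds.

Measured compounds:
- compound 1, `O=C(NC1CCC(O)CC1)N1CCC(c2nc(-c3ccc4ccccc4n3)no2)CC1`, 2700 nM
- compound 2, `Cn1c(-c2noc(N3CCN(C(=O)NC4CCCCC4)CC3)n2)nc2ccccc21`, 5 nM

In a functional assay on Shh Light II cells (Mus musculus) for inhibition, read by a luciferase reporter (on this read-out higher numbers stand for weaker inhibition and lower numbers for stronger inhibition), compound 1 gives 2700 nM, the higher of the two numbers in hand, so the weaker inhibitor. Compound 2 is built on a different core and gives 5 nM in this assay, a far lower number, well beyond the scatter of repeated measurements. No single change connects these two compounds, so their gap says nothing about any one group.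

Compound 3, `COc1ccccc1NC(=O)N1CCC(c2nc(-c3ccc4ccccc4n3)no2)CC1`, keeps the core of compound 1 and differs from it in one place: 2-methoxyphenyl in place of 4-hydroxycyclohexyl on an amide-type nitrogen. Going by the values given here, no pair of measured compounds shows this kind of change, so there is no direct guide to its effect. Compound 3 is expected to fall near compound 1 or somewhat lower, with the step of a 2.3-fold lower number from compound 1 to compound 3 (0.35 log units; beyond the scatter) as the estimate, and wide uncertainty in either direction. In this assay compound 3 is therefore estimated at 1200 nM, within a range from 200 nM to 8000 nM.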

Compound 3, half-maximal inhibitory concentration: 410 nM
The estimate for compound 3 lay 2.9-fold (0.47 log units) above the measured number; low and high end bracket the measured number.
By their numbers in this assay, from the lowest: compound 2; then compound 3; then compound 1.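

Going by these compounds alone, putting 2-methoxyphenyl in place of 4-hydroxycyclohexyl on the amide-type nitrogen gives a 6.6-fold lower number from compound 1 to compound 3 (0.82 log units; beyond the scatter) in this assay, the first sign that the group at this position matters for inhibition while the core of compound 1 stays fixed. A six-membered aromatic ring of carbon is accepted here, and the hydrogen-bond donor that leaves with 4-hydroxycyclohexyl is not needed to reach this level of inhibition. Nothing at hand explains why the swap lowers the number.

The ring and its substituent change together, so the compounds shown cannot separate the effect of the aromatic ring from that of the methoxy group; an unsubstituted phenyl would begin to do so. Going by these compounds, whether 2-methoxyphenyl would give a similar step on the core of compound 2 also stays open.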